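Removing One Chloro Group Across Four Cytotoxicity Analogues

This account rests on a few compounds, and the source may have more. Where it says the series, first, only, none or still open, it means among the compounds named here.

Compound 1 `ClCc1cccc(Cn2cnc3ncnc(Cl)c32)c1`, compound 2 `ClCc1ccc(Cn2cnc3nc(Cl)nc(Cl)c32)cc1` and compound 3 `ClCc1cccc(Cn2cnc3nc(Cl)nc(Cl)c32)c1` were tested in a functional assay on RPMI-8226 cells (Homo sapiens) for cytotoxicity, read by sulforhodamine B assay, with a stated time of 48 h; on this read-out lower numbers stand for higher toxicity in this test and higher numbers for lower toxicity in this test. Compound 1 gives 89100 nM and compound 2 gives 97700 nM in this assay; these two numbers sit within the usual scatter of each other. Compound 3 reached only a limit, (the limit of > 100000 nM in this assay, at which 1 of the 3 values shown sits), so its result is reported as > 100000 nM rather than as a number. Compound 1 differs from compound 3 by one change, (hydrogen in place of chloro on an aromatic carbon), and that step is an at least 1.1-fold lower number from compound 3 to compound 1 (0.05 log units; that floor lies within the scatter). Compound 4 `ClCc1ccc(Cn2cnc3ncnc(Cl)c32)cc1` is not yet measured; it differs from compound 2 by the same change, (hydrogen in place of chloro on an aromatic carbon). How the core of compound 2 differs from that of compound 3 is not broken down here. Compound 4 is expected to give 90000 nM in this assay, between 45000 nM and 180000 nM. That expectation rests on an at least 1.1-fold lower number from compound 3 to compound 1 (0.05 log units; that floor lies within the scatter). Compound 4 is therefore expected to show a 1.1-fold lower number from compound 2 to compound 4 (0.04 log units; within the scatter).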

Compound 4, concentration lethal to 50% of the cells: 5620 nM
Compound 4: middle estimate off by 16-fold (1.20 log units), on the high side; the whole stated range lies above it.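

In this assay hydrogen in place of chloro on an aromatic carbon gives a 17-fold lower number from compound 2 to compound 4 (1.24 log units; beyond the scatter), a large step on this core. This shows that the change can matter a great deal in this series, but it does not show whether the change carries over from one core to the other with the same size: the same change on two cores in this assay, an at least 1.1-fold lower number (0.05 log units; that floor lies within the scatter) from compound 3 to compound 1 and a 17-fold lower number (1.24 log units; beyond the scatter) from compound 2 to compound 4; the limit leaves it open whether they differ. Compound 3 gives only a limit, not a number: the limit of > 100000 nM in this assay, at which 1 of the 4 values shown sits.

The compounds shown leave open what an amine or a methoxy group would do on that same aromatic carbon. They also leave open whether the large step would survive with a hydroxymethyl group in place of the chloromethyl group.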